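The compounds below may be only part of what the source reports. "The series", "measured", "known", "first", "only" and "open" are said of these compounds alone.

Values in a functional assay on CEM-DNR-bulk cells (Homo sapiens), read by MTT assay, with a stated time of 72 h (on this read-out lower numbers stand for stronger inhibition and higher numbers for weaker inhibition), each of them a limit and not a number:
- compound 1 `CSc1ncnc2c1c(-c1ccccc1)cn2[C@@H]1O[C@H](CO)[C@@H](O)[C@H]1O`: > 20000 nM
- compound 2 `Nc1nc(N)c2c(-c3ccco3)cn([C@@H]3O[C@H](CO)[C@@H](O)[C@H]3O)c2n1`: > 20000 nM
- compound 3 `Cc1nc(N)c2c(-c3ccco3)cn([C@@H]3O[C@H](CO)[C@@H](O)[C@H]3O)c2n1`: > 20000 nM

Compound 3 has no number, only the limit > 20000 nM. Compound 4 `Cc1nc(N)c2c(-c3ccsc3)cn([C@@H]3O[C@H](CO)[C@@H](O)[C@H]3O)c2n1` differs from it in one place: thiophen-3-yl in place of furan-2-yl on an aromatic carbon. In words, thiophen-3-yl stands in place of furan-2-yl on an aromatic carbon. Within the data shown here, the only measured step, a step that the two limits leave unreadable from compound 2 to compound 3, is a different change and gives no size to carry over. No step beyond the scatter is expected in this assay because the limit of > 20000 nM in this assay, at which 3 of the 3 values shown sit, offers no measured size to go on. The estimated step is a number no higher from compound 3 to compound 4 (the limit leaves the size open). Compound 4 is expected near 20000 nM, with an estimated range of 6000 nM to 40000 nM.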

Compound 4, half-maximal inhibitory concentration: > 20000 nM
Compound 4: no number, only a limit; the forecaster's own chance of this, stated with the estimate: 70%; the middle value sits exactly at the limit.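

Compound 3 and compound 4 each carry only a limit and not a number, so the step between them cannot be read. Whether thiophen-3-yl in place of furan-2-yl changes inhibition at all stays open, with every value shown sharing one limit: the limit of > 20000 nM in this assay, at which 4 of the 4 values shown sit.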